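Dropping the amino group from compound 3

A few compounds are considered here, and "the series" means these few. Any claim that something is new, unique, unknown or untested is made for them only; others in the source may bear on it.

Compound 1 `CC(Nc1ncnc2ncc(-c3cnn(C)c3)cc12)c1c(Cl)ccc(F)c1Cl` in a functional assay on MCF7 cells (Homo sapiens) for antiproliferative activity, read by MTT assay, with a stated time of 72 h (on this read-out higher numbers stand for weaker inhibition and lower numbers for stronger inhibition), sits at the assay limit of > 100000 nM and gives no number. Compound 2 `COc1cccc(CNc2ncnc3ccc(-c4cnn(C)c4)cc23)c1` gives 40000 nM in this assay. Compound 3 `CC(Nc1nc(N)nc2ccc(-c3cnn(C4CCNCC4)c3)cc12)c1c(Cl)ccc(F)c1Cl` gives the lowest of the two numbers, 2230 nM, with compound 2 standing at the higher number, and that gap lies beyond the scatter. Compound 4 `CC(Nc1ncnc2ccc(-c3cnn(C4CCNCC4)c3)cc12)c1c(Cl)ccc(F)c1Cl` differs from compound 3 only in the change (hydrogen in place of amino on an aromatic carbon). Since no step between measured compounds is shown, compound 4 is expected to fall weaker than compound 3, by a step of a 3.6-fold higher number from compound 3 to compound 4 (0.55 log units; beyond the scatter) that lies beyond the scatter. Compound 4 is therefore estimated at 8000 nM, within 2000 nM to 40000 nM.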

Compound 4, half-maximal inhibitory concentration: 2650 nM
Estimate against measurement, compound 4: 3.0-fold (0.48 log units) above; low and high end bracket the measured number.
By their numbers in this assay, from the lowest: compounds 3 and 4 (each within the scatter of the next); then compound 2. At a limit, above all of these: compound 1.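

Replacing amino with hydrogen on the aromatic carbon between two ring nitrogen atoms gives, in this assay, a 1.2-fold higher number from compound 3 to compound 4 (0.07 log units; within the scatter), so this position accepts either on this read-out. This first one-place comparison shows that the amino group is not needed to hold the level of compound 3. No measured property shown bears on this result. From the compounds shown here alone, it remains open whether a methyl group, a methoxy group or a chlorine atom on this carbon would read the same. Going by these compounds, it also remains open whether the amino group would matter with a different group on the rest of the molecule.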